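Chloro for methoxy on the aryl amide: compound 4

The source may hold more compounds than are shown below. What is called first, only, known or untested is meant among the compounds shown, and "the series" means these compounds.

Measured in a functional assay on HeLa cells (Homo sapiens) for antiproliferative activity, read by MTT assay, with a stated time of 72 h; on this read-out lower numbers stand for stronger inhibition and higher numbers for weaker inhibition:
compound 1 `COc1ncc(-c2ccc3c(c2)N(c2ccc(C)cc2)C(=O)CO3)cc1NS(=O)(=O)c1ccc(F)cc1` gives 4650 nM;
compound 2 `Cc1ccc(N2C(=O)COc3ccc(-c4cnc(Cl)c(NS(=O)(=O)c5ccc(F)cc5)c4)cc32)cc1` gives 32300 nM;
compound 3 `COc1ccc(N2C(=O)COc3ccc(-c4cnc(OC)c(NS(=O)(=O)c5ccc(F)cc5)c4)cc32)cc1` gives 1220 nM.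

Compound 3 stands lowest of the three, with compound 1 nearest and compound 2 furthest. From compound 1 to compound 2 the change is chloro in place of methoxy on an aromatic carbon, and it made a 6.9-fold higher number from compound 1 to compound 2 (0.84 log units; beyond the scatter). From compound 1 to compound 3 the change is methoxy in place of methyl on an aromatic carbon, and it made a 3.8-fold lower number from compound 1 to compound 3 (0.58 log units; beyond the scatter).

Compound 4 `COc1ncc(-c2ccc3c(c2)N(c2ccc(Cl)cc2)C(=O)CO3)cc1NS(=O)(=O)c1ccc(F)cc1` has not yet been measured. From compound 3 to compound 4 the change is chloro in place of methoxy on an aromatic carbon. This is the same kind of change as from compound 1 to compound 2, but not the same: there it sat on a six-membered aromatic ring with one nitrogen, next to the ring nitrogen and ortho to a ((4-fluorophenyl)sulfonyl)amino group; here it sits on a six-membered aromatic ring of carbon only, para to a large group. The cores of compound 1 and compound 3 differ by methoxy in place of methyl on an aromatic carbon.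

Because compound 1 gave 4650 nM and compound 3 gave 1220 nM, the expected step from compound 3 to compound 4 is a 2.5-fold higher number from compound 3 to compound 4 (0.39 log units; beyond the scatter), smaller than the earlier one. Compound 4 is expected to give 3000 nM in this assay, between 1000 nM and 10000 nM.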

Compound 4, half-maximal inhibitory concentration: 4830 nM
Compound 4: middle estimate off by 1.6-fold (0.21 log units), on the low side, and the stated range covers the measured number.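

In this assay, chloro in place of methoxy gave a higher number on both cores, and the two steps agree: the same change on two cores in this assay, a 6.9-fold higher number (0.84 log units; beyond the scatter) from compound 1 to compound 2 and a 4.0-fold higher number (0.60 log units; beyond the scatter) from compound 3 to compound 4, 1.8-fold (0.24 log units) apart, within the scatter of two such steps. The new step reads a 4.0-fold higher number from compound 3 to compound 4 (0.60 log units; beyond the scatter), while setting chloro against methyl gives a 1.0-fold higher number from compound 1 to compound 4 (0.02 log units; within the scatter), so those two groups cannot be told apart here. The change thus carried over in direction and, within the scatter, in size, even though it sat on a different ring in each pair, but two pairs do not show that it would hold on other cores, and they do not explain it.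

The compounds shown leave open how an amine or a carboxylic acid would behave on the aromatic carbon para to a large group. They also leave open whether a longer alkoxy chain there would match methoxy.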